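Swapping Hydroxy for Chloro on a Shared Core

This account rests on a few compounds, and the source may have more. Where it says the series, first, only, none or still open, it means among the compounds named here.

Compound 1 `N=C(NO)N/N=C/c1ccc(O)cc1` was examined in an ADME assay on Vero cells (Chlorocebus sabaeus) for cytotoxicity; on this read-out lower numbers stand for higher toxicity in this test and higher numbers for lower toxicity in this test. In this assay compound 1 gives > 100000 nM, which is a limit of the assay rather than a number. Compound 2 `N=C(NO)N/N=C/c1ccccc1Cl` likewise gives > 100000 nM, again a limit. Among the measured compounds shown here, compound 1 therefore stands at the limit of > 100000 nM in this assay, at which 2 of the 2 values shown sit, and no measured step between compounds is available. Compound 3 `N=C(NO)N/N=C/c1ccc(Cl)cc1` differs from compound 1 by chloro in place of hydroxy on an aromatic carbon. With both shown values at the limit, the step of a number no higher from compound 1 to compound 3 (the limit leaves the size open) is expected to be none beyond the scatter. Compound 3 is accordingly estimated at 100000 nM, within a range from 50000 nM to 200000 nM.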

Compound 3, half-maximal cytotoxic concentration: > 100000 nM
Compound 3: no number, only a limit (the forecaster's own chance of this, stated with the estimate: 85%); the middle value lies on the limit itself.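

No step can be read between compound 1 and compound 3, since both results are limits and not numbers. The compounds shown leave open how far each lies beyond the limit, and whether chloro in place of hydroxy changes cytotoxicity at all: the limit of > 100000 nM in this assay, at which 3 of the 3 values shown sit.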